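A few compounds are considered here, and "the series" means these few. Any claim that something is new, unique, unknown or untested is made for them only; others in the source may bear on it.

Working notes on the series. Compound 1 `O=C(Nc1ccc(Cl)c(-c2nc3ccccc3[nH]2)c1)c1ccc(F)cc1` and compound 2 `O=C(Nc1ccc(Cl)c(-c2nc3ccccc3[nH]2)c1)c1ccc(Cl)cc1` share one core and differ only at the far ring of the amide. In a functional assay on Shh Light II cells for inhibition of Sonic hedgehog protein (Mus musculus), read by reporter gene assay, with a stated time of 48 h, in the presence of a further agent that is not named here (a higher number here means a weaker inhibitor, a lower number a stronger inhibitor), compound 1 gives 251 nM, and in the same assay compound 2 gives 224 nM. The step of a 1.1-fold lower number from compound 1 to compound 2 (0.05 log units; within the scatter) is the only one measured so far, so compound 2 holds the lower of two numbers that cannot be told apart.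

Compound 3 `CN(C)c1ccc(C(=O)Nc2ccc(Cl)c(-c3nc4ccccc4[nH]3)c2)cc1` follows from compound 2 by the change (dimethylamino in place of chloro on an aromatic carbon), in words dimethylamino in place of chloro on an aromatic carbon, para to a large group. Within the data shown here, no measured step covers a change of this kind; the one step available, a 1.1-fold lower number from compound 1 to compound 2 (0.05 log units; within the scatter), only shows that two halogens at this place give indistinguishable numbers. With nothing beyond that, compound 3 is expected to show a step of a 1.1-fold higher number from compound 2 to compound 3 (0.05 log units; within the scatter), and this is an estimate with no clear direction. Compound 3 is therefore estimated at 250 nM, in the range 80 nM to 800 nM.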

Compound 3, half-maximal inhibitory concentration: 190 nM
Estimate against measurement, compound 3: 1.3-fold (0.12 log units) above; the measured number falls inside the stated range.
By their numbers in this assay, from the lowest: compounds 3, 2 and 1 (each within the scatter of the next).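

In this assay the step is a 1.2-fold lower number from compound 2 to compound 3 (0.07 log units; within the scatter), so 4-(dimethylamino)phenyl cannot be told apart from 4-chlorophenyl at this place. Against the fluoro compound the reading is the same, with a 1.3-fold lower number from compound 1 to compound 3 (0.12 log units; within the scatter), which extends the earlier result beyond two halogens: dimethylamino, with 3 heavy atoms and 1 hydrogen-bond acceptor, stands here in place of a single halogen atom without a step beyond the scatter. Nothing available gives a reason for this flat reading.

The compounds shown leave open whether a carboxylic acid, a primary amine or a longer chain at this place would give a step beyond the scatter. On these data alone, all three compounds share one core and vary at this place only, so it also remains open whether the flat reading would hold on a changed core.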